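Moving the Halogen on the Anilino Ring

The source may report more compounds than this note shows. Statements on the series, on what has been measured and on what is new or still open speak of the compounds shown alone.

Among the compounds with values here, compound 2 `CCOC(=O)C1=C(Nc2ccccc2Br)S/C(=C\c2ccc[nH]2)C1=O` is the only member of this set with a measured number in a functional assay on MCF7 cells (Homo sapiens) for inhibition, read by MTT assay, with a stated time of 72 h, tested at 10 uM (on this read-out lower numbers stand for less inhibition and higher numbers for more inhibition at the one concentration tested (going by the name of the read-out)), where compound 2 gives 29.4%. Compound 1 `CCOC(=O)C1=C(Nc2ccc(Br)cc2)S/C(=C\c2ccc[nH]2)C1=O` reaches only a limit in this assay, giving < 10% (the limit of < 10% in this assay, at which 1 of the 2 values shown sits). Within the data shown here, the single measured step, a number at least 19.4 percentage points higher from compound 1 to compound 2 (beyond the scatter), came with 2-bromophenyl in place of 4-bromophenyl on an amine nitrogen. Compound 3 `CCOC(=O)C1=C(Nc2cccc(F)c2)S/C(=C\c2ccc[nH]2)C1=O` differs from compound 2 by 3-fluorophenyl in place of 2-bromophenyl on an amine nitrogen. Among the measured compounds shown here, no measured pair covers a bromine-to-fluorine swap, so the expected change in this assay, a number 11.4 percentage points lower from compound 2 to compound 3 (beyond the scatter), is estimated as modest and downward. Compound 3 is estimated to give 18%, between 5% and 35%.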

Compound 3, a percentage reported as inhibition, at one concentration (the size of the read-out at that concentration, not a potency): < 10%
Compound 3 ended at the assay's limit; the forecaster's own chance of this, stated with the estimate: 30%; middle value at least 8 percentage points away from the limit.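

In this assay, replacing 2-bromophenyl with 3-fluorophenyl on the amine nitrogen gives a number at least 19.4 percentage points lower from compound 2 to compound 3 (beyond the scatter), so a second change away from 2-bromophenyl, this time altering both the halogen and the group's name position, also falls to a limit. Compound 2 therefore stands alone among the three with a measured number, and the other two compounds rest on the same limit: the limit of < 10% in this assay, at which 2 of the 3 values shown sit. Because both are limits, the step between compound 1 and compound 3 cannot be read: the limit of < 10% in this assay, at which 2 of the 3 values shown sit.

Going by these compounds, it remains open whether the higher number is specific to 2-bromophenyl, or whether 2-chlorophenyl, 2-fluorophenyl or 2-methylphenyl on the same amine nitrogen would give a similar reading.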